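From Compound 1 to Compound 3: an Untested Change

The source may report more compounds than this note shows. Statements on the series, on what has been measured and on what is new or still open speak of the compounds shown alone.

Two compounds share a common core and are compared in a functional assay on OVCAR-3 cells (Homo sapiens) for antiproliferative activity, read by MTT assay, with a stated time of 24 h; a higher number here means a weaker inhibitor, a lower number a stronger inhibitor. Compound 1 `O=C(NNc1ccccc1Cl)c1cccc(NS(=O)(=O)c2cnc(O)nc2O)c1` gives 3350 nM in this assay. Compound 2 `O=C(NNc1ccc(F)cc1)c1ccccc1NS(=O)(=O)c1cnc(O)nc1O` is built from the same parts in a different arrangement. In this assay compound 2 reaches only > 20000 nM, which is a limit of the measurement and not a number. Going by the values given here, compound 1 therefore holds the only numeric value shown, while the other reading sits at the limit of > 20000 nM in this assay, at which 1 of the 2 values shown sits. Among the compounds with values here, compound 1 and compound 2 differ in more than one place, so no single step can be drawn between them; their two values show simply one number and one limit.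

Compound 3 `O=C(NNC(=O)c1ccccc1F)c1cccc(NS(=O)(=O)c2cnc(O)nc2O)c1` has not yet been measured. It differs from compound 1 at a single site: (2-fluorophenyl)carbonyl in place of 2-chlorophenyl on an amine nitrogen. Within the data shown here, no measured pair shows the effect of such a change, so the size of the step remains open. The expected step from compound 1 to compound 3 is a 1.5-fold higher number from compound 1 to compound 3 (0.17 log units; within the scatter), a mild weakening that need not exceed the scatter. Compound 3 is accordingly expected to give about 5000 nM in this assay, within a range from 1500 nM to 20000 nM.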

Compound 3, half-maximal inhibitory concentration: 10800 nM
Beside the measured number, compound 3's estimate is 2.2-fold (0.33 log units) below it, and the stated range covers the measured number.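

Going by these compounds alone, this is the first measured step at this site, an amine nitrogen whose other neighbour is an amide-type nitrogen. In this assay, putting (2-fluorophenyl)carbonyl in place of 2-chlorophenyl gives a 3.2-fold higher number from compound 1 to compound 3 (0.51 log units; beyond the scatter), so the number does respond to what sits on this nitrogen, though the step is modest in size. The change also brings in a carbonyl and swaps chlorine for fluorine in one move, and compound 3 still gives a measured number, 10800 nM, so this larger group weakens the compound without taking the reading out of measurable range. Nothing shown here bears on why the number rises.

The compounds shown leave open how much of the step belongs to the carbonyl and how much to the exchange of chlorine for fluorine, a split that a 2-fluorophenyl group or a (2-chlorophenyl)carbonyl group on the same nitrogen would help to settle. Also open, on these data alone, is how this nitrogen would read with a quite different group, such as an acetyl group or a chain ending in a carboxylic acid.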